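Chain-extended succinate esters of the shared quinazoline-free core series

The source may hold more compounds than are shown below. What is called first, only, known or untested is meant among the compounds shown, and "the series" means these compounds.

Working notes on the ester tail of this series. Compound 1 `CCCCCOC(=O)CCC(=O)N1CCN(CCCOc2cc3c(Nc4ccc(F)c(Cl)c4)ncnc3cc2OC)CC1` in a functional assay on A549 cells (Homo sapiens) for cytotoxicity, read by MTT assay, with a stated time of 24 h, tested at 20 uM (on this read-out lower numbers stand for a stronger effect and higher numbers for a weaker effect at the one concentration tested), gives 81.2%. Among the compounds with values here, compound 2 `CCCCCCCCCCCCOC(=O)CCC(=O)N1CCN(CCCOc2cc3c(Nc4ccc(F)c(Cl)c4)ncnc3cc2OC)CC1` in this assay gives 86.8%, the highest of the two numbers so far, though its step from compound 1 is a number 5.6 percentage points higher from compound 1 to compound 2 (within the scatter), so the two compounds cannot be ranked against each other. The next compound, compound 3 `CCCCCCCCCCCCCCCCCCCCOC(=O)CCC(=O)N1CCN(CCCOc2cc3c(Nc4ccc(F)c(Cl)c4)ncnc3cc2OC)CC1`, differs from compound 2 by octyl in place of hydrogen on a saturated chain carbon, ten or more bonds along the chain from an oxygen next to a carbonyl group. Within the data shown here, the only measured step that bears on this change is the one from compound 1 to compound 2, a lengthening of the same ester chain, which read a number 5.6 percentage points higher from compound 1 to compound 2 (within the scatter); that step stayed within the scatter. The expectation for the step from compound 2 to compound 3 in this assay is therefore no change beyond the scatter, estimated as a number 1.2 percentage points higher from compound 2 to compound 3 (within the scatter). For compound 3 the value in this assay is estimated at 88%, with a range from 76% to 98%.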

Compound 3, a percentage reported as activity, at one concentration (the size of the read-out at that concentration, not a potency): 90.8%
Estimate against measurement, compound 3: 2.8 percentage points below; the measured number falls inside the stated range.
By their numbers in this assay, from the lowest: compounds 1, 2 and 3 (each within the scatter of the next).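

Octyl in place of hydrogen on a saturated chain carbon reads in this assay as a number 4 percentage points higher from compound 2 to compound 3 (within the scatter). A second lengthening of the same ester chain, now with the added carbons far out along it, therefore also stays inside the scatter, so compound 3 cannot be ranked against compound 2. Nothing available explains this reading.

Still open, on these data alone, is whether a methyl ester, a carboxylic acid in place of the ester, or an amine at the end of the chain would give a step beyond the scatter. As far as these compounds go, with a single tested concentration, whether compounds 1, 2 and 3 would show a stronger or weaker effect at any other concentration also remains open.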